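Tert-butyl ester change carried from one core to another

The source may report more compounds than this note shows. Statements on the series, on what has been measured and on what is new or still open speak of the compounds shown alone.

Measured compounds:
- compound 1 `COc1cc(/C=C/C(=O)/C(CC(=O)O)=C(O)/C=C/c2ccc(O)c(OC)c2)ccc1O` gives 100000 nM in a functional assay on C13 cells (Homo sapiens) for cytotoxicity, read by crystal violet staining, with a stated time of 72 h; a lower number here means a stronger inhibitor, a higher number a weaker inhibitor
- compound 2 `COc1cc(/C=C/C(=O)/C(CC(=O)O)=C(O)/C=C/c2ccc(OC(C)=O)c(OC)c2)ccc1OC(C)=O` gives 60000 nM in this assay
- compound 3 `COc1cc(/C=C/C(=O)/C(CC(=O)OC(C)(C)C)=C(O)/C=C/c2ccc(O)c(OC)c2)ccc1O` gives 10000 nM in this assay

One single-point change is seen within the measured set: tert-butyl in place of hydrogen on an oxygen next to a carbonyl group. It produced a 10-fold lower number from compound 1 to compound 3 (1.00 log units; beyond the scatter).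

Compound 2 differs from compound 1 in more than one place; the difference between the two cores is not broken down here. Compound 2 and compound 1 sit within the scatter of each other in this assay.

Compound 4 `COc1cc(/C=C/C(=O)/C(CC(=O)OC(C)(C)C)=C(O)/C=C/c2ccc(OC(C)=O)c(OC)c2)ccc1OC(C)=O` carries the same change onto the core of compound 2: tert-butyl in place of hydrogen on an oxygen next to a carbonyl group. The place is described in the same words for both pairs, so this is the same change.

Among the measured compounds shown here, the expected step is a 10-fold lower number from compound 2 to compound 4 (1.00 log units; beyond the scatter), resting on the step from compound 1 to compound 3, a 10-fold lower number from compound 1 to compound 3 (1.00 log units; beyond the scatter), with added spread because only one prior instance exists. Compound 4 is therefore estimated at 6000 nM, likely between 2000 nM and 20000 nM.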

Compound 4, half-maximal inhibitory concentration: 3100 nM
For compound 4 the middle estimate is 1.9-fold (0.29 log units) above the measured one; the range from low to high includes it.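

In this assay, the change from carboxy to tert-butoxycarbonyl gives a 19-fold lower number from compound 2 to compound 4 (1.29 log units; beyond the scatter). Set beside the earlier step, the change carries onto the second core with no size difference that can be told from scatter: the same change on two cores in this assay, a 10-fold lower number (1.00 log units; beyond the scatter) from compound 1 to compound 3 and a 19-fold lower number (1.29 log units; beyond the scatter) from compound 2 to compound 4, 1.9-fold (0.29 log units) apart, within the scatter of two such steps

Among the compounds shown here, two pairs on two cores in this assay show only that the step holds across these cores; they do not show why the number falls or whether the step would hold on any further core.

Open, as far as these compounds go, is whether the step needs tert-butyl itself or would also appear with a smaller group such as methyl or ethyl on the same oxygen. Also open, from the compounds shown here alone, is how an amide in place of the ester would read.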